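Hydroxynaphthoquinone–indole series: replacing the aryl arm

A few compounds are considered here, and "the series" means these few. Any claim that something is new, unique, unknown or untested is made for them only; others in the source may bear on it.

Measured compounds:
- Compound 1, `Cc1[nH]c2ccccc2c1C(C1=C(O)C(=O)c2ccccc2C1=O)c1ccc(Cl)cc1`: 14300 nM
- Compound 2, `COc1ccc(C(C2=C(O)C(=O)c3ccccc3C2=O)c2c[nH]c3ccccc23)cc1Br`: 11800 nM
- Compound 3, `O=C1C(O)=C(C(c2cccc([N+](=O)[O-])c2)c2c(-c3ccccc3)[nH]c3ccccc23)C(=O)c2ccccc21`: 5830 nM

The numbers come from a functional assay on ECa-109 cells (Homo sapiens) for cytotoxicity, read by MTT assay, with a stated time of 48 h; a lower number here means a stronger inhibitor, a higher number a weaker inhibitor. In this assay compound 2 gives 11800 nM, the second highest of the three values. Compound 1 gives 14300 nM, which lies within the scatter of compound 2, so no order can be read between these two. Among the compounds with values here, compound 3 gives 5830 nM, a lower number than that of compound 2 and beyond the scatter; since compound 3 differs from compound 2 in more than one place, the two values show only that compound 3 is the stronger of the pair, not which change is responsible.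

Compound 4, `O=C1C(O)=C(C(c2cccs2)c2c[nH]c3ccccc23)C(=O)c2ccccc21`, has not yet been measured in this assay. Its change from compound 2 is thiophen-2-yl in place of 3-bromo-4-methoxyphenyl on a saturated chain carbon bound to an aromatic carbon and a double-bonded ring carbon. Within the data shown here, no measured pair in the set isolates a change of this kind, so there is no comparable step to lean on. The expectation is therefore a step from compound 2 to compound 4 of a 1.1-fold higher number from compound 2 to compound 4 (0.04 log units; within the scatter), not beyond the scatter in either direction. Compound 4 is estimated to give 13000 nM in this assay, with a range from 5500 nM to 32000 nM.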

Compound 4, half-maximal inhibitory concentration: 12100 nM
Estimate against measurement, compound 4: 1.1-fold (0.03 log units) above, and the stated range covers the measured number.
By their numbers in this assay, from the lowest: compound 3; then compounds 2, 4 and 1 (each within the scatter of the next).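

In this assay, the series now has its first step that can be read at a single place: a 1.0-fold higher number from compound 2 to compound 4 (0.01 log units; within the scatter), within the scatter. On a saturated chain carbon bound to an aromatic carbon and a double-bonded ring carbon, the exchange of 3-bromo-4-methoxyphenyl, with 9 heavy atoms, for thiophen-2-yl, with 5 heavy atoms, therefore gives no readable change in the number, so for this pair neither the six-membered aromatic ring of carbon only nor its bromine and methoxy substituents are needed to keep the value of compound 2. No measured property bears on why the two values stay together.

The value of compound 3, 5830 nM, remains unassigned to any single change in its structure. Also open, as far as these compounds go, is whether another kind of group at this place, such as an aryl arm carrying an amine or a carboxylic acid, or a saturated alkyl chain in place of the aromatic ring, would move the number beyond the scatter.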